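Allenylamine series: methyl on the aromatic ring

The compounds below may be only part of what the source reports. "The series", "measured", "known", "first", "only" and "open" are said of these compounds alone.

Compound 2 `C=C=C(CN)Cc1ccccc1` gives 12 umol/kg in an assay on forebrain for inhibition of Monoamine oxidase (Mus musculus); on this read-out lower numbers stand for an effect already at smaller amounts and higher numbers for an effect only at larger amounts of compound; compound 1 `C=C=CCN(C)Cc1ccccc1` gives 17 umol/kg in this assay, and compound 2 stands alongside it, the two values within the usual scatter of each other. Compound 3 `C=C=C(CN)Cc1ccc(C)cc1` differs from compound 2 by methyl in place of hydrogen on an aromatic carbon. Among the compounds with values here, no pair of measured compounds shows the effect of such a change, so no shift beyond the scatter is expected in either direction. Compound 3 is expected to give 12 umol/kg in this assay, with a range from 5 umol/kg to 30 umol/kg. The step of no change at the digits printed from compound 2 to compound 3 (within the scatter) is expected to stay within the scatter.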

Compound 3, dose for half-maximal effect: 23 umol/kg
Estimate against measurement, compound 3: 1.9-fold (0.28 log units) below, and the stated range covers the measured number.
By their numbers in this assay, from the lowest: compounds 2, 1 and 3 (each within the scatter of the next).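

Methyl in place of hydrogen on this aromatic carbon gives a 1.9-fold higher number from compound 2 to compound 3 (0.28 log units; within the scatter) in this assay, the first reading of a substituent on this ring. At this place, on the aromatic carbon para to a group of 6 heavy atoms, the methyl group therefore leaves the number within the scatter. Nothing at hand bears on what lies behind this result.

As far as these compounds go, it remains open whether methoxy, chlorine or a carboxylic acid at the same carbon would move the number beyond the scatter. From the compounds shown here alone, it also remains open whether methyl on another carbon of the ring would behave like the methyl group of compound 3.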